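Phenylpropargyl hydrazone sulfonylguanidines: shifting the benzylsulfanyl chlorine

This account rests on a few compounds, and the source may have more. Where it says the series, first, only, none or still open, it means among the compounds named here.

Compound 1 `Cc1cc(S(=O)(=O)/N=C(\N)N/N=C/C#Cc2ccccc2)c(SCc2ccccc2Cl)cc1Cl` is the reference point of the set. In a functional assay on HeLa cells (Homo sapiens) for antiproliferative activity, read by MTT assay, with a stated time of 72 h (on this read-out higher numbers stand for weaker inhibition and lower numbers for stronger inhibition), compound 1 gives 14000 nM. Compound 2 `C/C(C#Cc1ccccc1)=N\N/C(N)=N/S(=O)(=O)c1cc(C)c(Cl)cc1SCc1ccccc1Cl` carries the change (a group of 11 heavy atoms (10 carbon, 1 nitrogen; one six-membered aromatic ring of carbon only) in place of a group of 10 heavy atoms (9 carbon, 1 nitrogen; one six-membered aromatic ring of carbon only), on an amine nitrogen). In this assay, within the data shown here, compound 2 gives 25000 nM, and the step of a 1.8-fold higher number from compound 1 to compound 2 (0.25 log units; within the scatter) is the only measured instance of this change. Compound 3 `Cc1cc(S(=O)(=O)/N=C(\N)N/N=C/C#Cc2ccccc2)c(SCc2ccc(Cl)cc2)cc1Cl` differs from compound 1 by 4-chlorophenyl in place of 2-chlorophenyl on a saturated chain carbon bound to a sulfur. In this assay compound 3 gives 6000 nM, the step being a 2.3-fold lower number from compound 1 to compound 3 (0.37 log units; beyond the scatter).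

Compound 4 `C/C(C#Cc1ccccc1)=N\N/C(N)=N/S(=O)(=O)c1cc(C)c(Cl)cc1SCc1ccc(Cl)cc1` has not been measured in this assay. It relates to compound 3 as compound 2 relates to compound 1: the change (a group of 11 heavy atoms (10 carbon, 1 nitrogen; one six-membered aromatic ring of carbon only) in place of a group of 10 heavy atoms (9 carbon, 1 nitrogen; one six-membered aromatic ring of carbon only), on an amine nitrogen), at the same place, the same change as before. The cores of compound 3 and compound 1 differ only in the chlorine position on the benzyl group, as given above.

With one prior instance, the expectation for compound 4 in this assay is a step of about the same size, a 1.7-fold higher number from compound 3 to compound 4 (0.22 log units; within the scatter), because the earlier step of a 1.8-fold higher number from compound 1 to compound 2 (0.25 log units; within the scatter) was small and within the scatter. The number expected for compound 4 in this assay is therefore 10000 nM, with a range from 5000 nM to 25000 nM.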

Compound 4, half-maximal inhibitory concentration: 8000 nM
Beside the measured number, compound 4's estimate is 1.3-fold (0.10 log units) above it; low and high end bracket the measured number.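

In this assay, the group of 11 heavy atoms in place of the group of 10 heavy atoms on the amine nitrogen again leaves only a small step, a 1.3-fold higher number from compound 3 to compound 4 (0.12 log units; within the scatter), so this change carries over from the core of compound 1 to the core of compound 3 with no difference that can be told from scatter: the same change on two cores in this assay, a 1.8-fold higher number (0.25 log units; within the scatter) from compound 1 to compound 2 and a 1.3-fold higher number (0.12 log units; within the scatter) from compound 3 to compound 4, 1.3-fold (0.13 log units) apart, within the scatter of two such steps

The reverse view holds as well: 4-chlorophenyl in place of 2-chlorophenyl gives a 3.1-fold lower number from compound 2 to compound 4 (0.49 log units; beyond the scatter), which matches its earlier step in direction and size: the same change on two cores in this assay, a 2.3-fold lower number (0.37 log units; beyond the scatter) from compound 1 to compound 3 and a 3.1-fold lower number (0.49 log units; beyond the scatter) from compound 2 to compound 4, 1.3-fold (0.13 log units) apart, within the scatter of two such steps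

This shows that the two changes behave independently across this one square of compounds, but it rests on a single pair per change and does not show that either step would hold on any other core.

On these data alone, whether the step from 2-chlorophenyl to 4-chlorophenyl is specific to chlorine remains open, since a fluorine or a methoxy group at that place would be needed to tell. Also open, as far as these compounds go, is how a longer chain on the sulfur would fare in this assay.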